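The source may report more compounds than this note shows. Statements on the series, on what has been measured and on what is new or still open speak of the compounds shown alone.

In a physicochemical assay for lipophilicity, using the shake flask method, in phosphate buffer, measured as octanol-water partition, with a stated time of 30 min, at pH 7.4 (a lower number here means a more polar compound, a higher number a more lipophilic compound), compound 1 `CC(=O)N1CCC(c2cnc(NCc3c(F)ccc4c3CCO4)c3cn[nH]c(=O)c23)CC1` gives 2.9, the highest of the three numbers measured and beyond the scatter of the other two. Compound 2 `CC1(C)CC(=O)N(c2cnc(NCc3c(F)ccc4c3CCO4)n3cnnc23)C1` gives 2, and compound 3 `O=C(Nc1cnc(NCc2c(F)ccc3c2CCO3)n2cnnc12)c1cccnc1` gives 2. Compound 4 `CNC(=O)c1cc(-c2cnc(NCc3c(F)ccc4c3CCO4)c3cn[nH]c(=O)c23)n(C)n1` keeps the core of compound 1 and differs in one place, on an aromatic carbon: 1-methyl-3-(methylcarbamoyl)-1H-pyrazol-5-yl in place of 1-acetylpiperidin-4-yl on an aromatic carbon. Within the data shown here, no measured step starts from the core of compound 1. Among the measured compounds shown here, the only step available, on a different core, is no change at the digits printed from compound 2 to compound 3 (within the scatter), and it exchanges other groups. On that thin guide, no step beyond the scatter is expected in this assay, with a slight lean downward. The estimated step is a number 0.20 log units lower from compound 1 to compound 4 (within the scatter). The expected value for compound 4 is 2.7, with an estimated range from 2.2 to 3.2.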

Compound 4, distribution coefficient: 2.1
The estimate for compound 4 lay 0.60 log units above the measured number, outside the stated range (below it).
By their numbers in this assay, from the lowest: compounds 2, 3 and 4 (each within the scatter of the next); then compound 1.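

In this assay, among these compounds, this is the first step read on the core of compound 1, and it shows that this position responds to the group it carries: 1-methyl-3-(methylcarbamoyl)-1H-pyrazol-5-yl in place of 1-acetylpiperidin-4-yl gives a number 0.80 log units lower from compound 1 to compound 4 (beyond the scatter). Among the compounds shown here, the only earlier step, on another core, stayed within the scatter. No measurement here accounts for this step.

Going by these compounds, the aromatic ring and the methylcarbamoyl group enter together, and which of them carries the step remains open. On these data alone, how a simple amine or a carboxylic acid on this carbon would read in this assay also remains open.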